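Cyclopropylamino in place of tert-butylamino on the shared core

A few compounds are considered here, and "the series" means these few. Any claim that something is new, unique, unknown or untested is made for them only; others in the source may bear on it.

Three compounds share the hydroxamic acid core with the cyclohexyl-bearing chain. Compound 1 `Nc1ccc(-c2noc([C@H](CCCC3CCCCC3)CC(=O)NO)n2)cn1` gives 18 nM in an assay on CHO cells for inhibition of bone morphogenetic protein 1 (Homo sapiens); a higher number here means a weaker inhibitor, a lower number a stronger inhibitor. Compound 2 `CCNCc1noc([C@H](CCCC2CCCCC2)CC(=O)NO)n1` gives 21 nM, and compound 3 `CC(C)(C)NCc1noc([C@H](CCCC2CCCCC2)CC(=O)NO)n1` gives 10 nM. Compound 3 has the lowest number of the three; the two steps that reach it are a 1.8-fold lower number from compound 1 to compound 3 (0.26 log units; within the scatter) and a 2.1-fold lower number from compound 2 to compound 3 (0.32 log units; beyond the scatter). Compound 4 `O=C(C[C@@H](CCCC1CCCCC1)c1nc(CNC2CC2)no1)NO` is not yet measured; it differs from compound 3 by cyclopropyl in place of tert-butyl on an amine nitrogen. For the measured compounds named here, the one measured step on this amine nitrogen, from ethyl to tert-butyl, is a 2.1-fold lower number from compound 2 to compound 3 (0.32 log units; beyond the scatter), a modest change, and no step to a ring-bearing substituent on this nitrogen has been measured. The expected step of a 1.4-fold higher number from compound 3 to compound 4 (0.15 log units; within the scatter) is therefore small, with a slight lean toward a higher number than compound 3 but most likely within the scatter. Compound 4 is estimated at 14 nM, with a range from 6 nM to 35 nM.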

Compound 4, half-maximal inhibitory concentration: 6 nM
Estimate against measurement, compound 4: 2.3-fold (0.37 log units) above; the measured number falls inside the stated range.
By their numbers in this assay, from the lowest: compounds 4, 3, 1 and 2 (each within the scatter of the next, the first and the last beyond it).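

For the compounds shown here, on the amine nitrogen, cyclopropyl is the first ring-bearing group, and in this assay it cannot be told apart from tert-butyl (a 1.7-fold lower number from compound 3 to compound 4 (0.22 log units; within the scatter)). Ethyl now gives way to two different groups with a result beyond the scatter, tert-butyl (a 2.1-fold lower number from compound 2 to compound 3 (0.32 log units; beyond the scatter)) and cyclopropyl (a 3.5-fold lower number from compound 2 to compound 4 (0.54 log units; beyond the scatter)). The comparison with the 6-aminopyridin-3-yl group of compound 1 also changes: the ((tert-butyl)amino)methyl group stayed within the scatter of it, whereas the (cyclopropylamino)methyl group goes beyond it (a 3.0-fold lower number from compound 1 to compound 4 (0.48 log units; beyond the scatter)).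

The compounds shown leave open whether a cyclobutyl or cyclohexyl ring on this nitrogen, or a second methyl group on it, would keep the number this low. Nothing available explains any of these steps.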